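Swapping a chloropyridinylamino for a methyl-oxazolyl group

The compounds below may be only part of what the source reports. "The series", "measured", "known", "first", "only" and "open" are said of these compounds alone.

Of the compounds shown here, two sharing one core have been measured in a functional assay on A375P cells (Homo sapiens) for antiproliferative activity; a lower number here means a stronger inhibitor, a higher number a weaker inhibitor. Compound 1 `Cc1ccc(NC(=O)Nc2ccc(C)c(NC(=O)c3ccccc3)c2)cc1C` reaches only the limit of this assay, > 30000 nM. For the measured compounds named here, compound 2 `Cc1ccc(NC(=O)Nc2ccc(Cl)nc2)cc1NC(=O)c1ccccc1` gives 1600 nM in this assay, the only firm number in the set. Going by the values given here, the single measured step, an at least 18-fold lower number from compound 1 to compound 2 (1.27 log units; beyond the scatter), shows that changing the group on the amide-type nitrogen matters greatly, with the weaker partner sitting at the limit of > 30000 nM in this assay, at which 1 of the 2 values shown sits.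

Compound 3 `Cc1cc(C(=O)Nc2ccc(C)c(NC(=O)c3ccccc3)c2)no1` is not yet measured. It differs from compound 2 by 5-methyl-1,2-oxazol-3-yl in place of (6-chloropyridin-3-yl)amino on a carbonyl carbon. Among the compounds with values here, no measured step touches the carbonyl carbon itself, so the bearing of the step from compound 1 to compound 2 is indirect; it shows only that this region is sensitive. Compound 3 is expected to give a higher number, a 5.0-fold higher number from compound 2 to compound 3 (0.70 log units; beyond the scatter), an estimate of 8000 nM with a range from 2000 nM to 30000 nM.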

Compound 3, half-maximal inhibitory concentration: > 30000 nM
Compound 3: only a limit was reported; the forecaster's own chance of this, stated with the estimate: 25%; middle value at least 3.7-fold (0.57 log units) away from the limit.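

In this assay, putting 5-methyl-1,2-oxazol-3-yl in place of (6-chloropyridin-3-yl)amino on the carbonyl carbon gives an at least 18-fold higher number from compound 2 to compound 3 (1.27 log units; beyond the scatter). A second, quite different replacement of the (6-chloropyridin-3-yl)amino group has now lost the firm number, so the sensitivity at this position no longer rests on the (3,4-dimethylphenyl)amino group of compound 1 alone. The value for compound 3 is a limit and not a number, and the step from compound 1 to compound 3 cannot be read, since two limits cannot be compared: the limit of > 30000 nM in this assay, at which 2 of the 3 values shown sit.

The compounds shown leave open whether the chlorine itself matters, as a plain (pyridin-3-yl)amino group would test. They also leave open whether an amino nitrogen joining the 5-methyl-1,2-oxazol-3-yl ring to the carbonyl carbon would give a firm number.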